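The compounds below may be only part of what the source reports. "The series", "measured", "known", "first", "only" and "open" are said of these compounds alone.

Compound 1 `CCOC(=O)C1=C(C)NC(C)=C(C(=O)OC)C1c1[nH]c(CC)nc1Cl`: 2.02 nM
Compound 2 `CCc1nc(Cl)c(C2C(C(=O)OC)=C(C)NC(C)=C2C(=O)OC(C)(C)C)[nH]1`: 50.8 nM

In an assay on ileum for inhibition of Voltage-dependent L-type calcium channel subunit alpha-1C (Cavia porcellus) (a higher number here means a weaker inhibitor, a lower number a stronger inhibitor), compound 1 gives 2.02 nM, the lowest of the two numbers measured. Going by the values given here, its nearest neighbour is compound 2, which in this assay gives 50.8 nM; the step between them, a 25-fold higher number from compound 1 to compound 2 (1.40 log units; beyond the scatter), is the only measured change at an ester group of the shared core.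

Compound 3 `CCOC(=O)C1=C(C)NC(C)=C(C(=O)OCc2ccccc2)C1c1[nH]c(CC)nc1Cl` differs from compound 1 by phenyl in place of hydrogen on a saturated chain carbon bound to an oxygen next to a carbonyl group, so that the methoxycarbonyl of compound 1 becomes benzyloxycarbonyl while its ethyl ester is kept. Among the compounds with values here, no measured pair covers this exact change. Within the data shown here, the one step that bears on it, a 25-fold higher number from compound 1 to compound 2 (1.40 log units; beyond the scatter), concerns the ethyl ester rather than the methyl one and replaced ethyl by tert-butyl rather than adding a phenyl, so it is only a loose guide; it does show that enlarging an ester group on this core can cost a great deal. Compound 3 is therefore expected to give a higher number than compound 1, the step estimated as a 4.0-fold higher number from compound 1 to compound 3 (0.60 log units; beyond the scatter), smaller than the measured loss to compound 2. The estimate for compound 3 in this assay is 8 nM, with a range from 2 nM to 40 nM.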

Compound 3, half-maximal inhibitory concentration: 2.66 nM
Estimate against measurement, compound 3: 3.0-fold (0.48 log units) above, within the range that was stated.
By their numbers in this assay, from the lowest: compounds 1 and 3 (each within the scatter of the next); then compound 2.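

In this assay, going by these compounds alone, the change to benzyloxycarbonyl is the first measured change at the methoxycarbonyl of compound 1, and the step (a 1.3-fold higher number from compound 1 to compound 3 (0.12 log units; within the scatter)) shows that this ester group can carry a phenyl on its saturated chain carbon bound to an oxygen next to a carbonyl group with no difference that can be told from the scatter. The earlier step (a 25-fold higher number from compound 1 to compound 2 (1.40 log units; beyond the scatter)) lies at the other ester group and is a different change, so the large loss seen there does not hold for every enlargement of an ester group on the shared core, and compound 3 stands against any such rule. No measured information on the compounds offers an explanation for this result.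

The compounds shown leave open how far this holds at the same place, for instance with a longer chain ending in phenyl or with an amine on the chain. They also leave open whether tert-butyl in place of methyl would cost as much here as it does at the ethyl ester, and whether benzyl would be accepted at the ethyl ester.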